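From 4-chlorophenyl to phenyl on the shared core

The compounds below may be only part of what the source reports. "The series", "measured", "known", "first", "only" and "open" are said of these compounds alone.

Measured in a functional assay on MCF7 cells (Homo sapiens) for antiproliferative activity, read by MTT assay, with a stated time of 72 h; on this read-out lower numbers stand for stronger inhibition and higher numbers for weaker inhibition:
Compound 1 `COc1cccc(N2C(=O)COc3ccc(-c4cccc(NS(=O)(=O)c5ccc(F)cc5)c4)cc32)c1`: > 40000 nM (a limit)
Compound 2 `O=C1COc2ccc(-c3cccc(NS(=O)(=O)c4ccc(F)cc4)c3)cc2N1c1ccc(Cl)cc1`: 39800 nM

For the measured compounds named here, compound 2 is the only compound here with an actual number, and that number lies close to the limit of the assay. Compound 1 reports only a limit. The next compound, compound 3 `O=C1COc2ccc(-c3cccc(NS(=O)(=O)c4ccc(F)cc4)c3)cc2N1c1ccccc1`, drops the chlorine of compound 2, a change from 4-chlorophenyl to phenyl: hydrogen in place of chloro on an aromatic carbon. Going by the values given here, only one measured step bears on this, a number no higher from compound 1 to compound 2 (the limit leaves the size open). It exchanges the same aryl group on the amide-type nitrogen in the ring, but it gives no readable size to carry over. With nothing to suggest a large shift in either direction, the expectation in this assay stays anchored on compound 2 at 39800 nM. The expected change is no step beyond the scatter, written as a 1.2-fold lower number from compound 2 to compound 3 (0.09 log units; within the scatter). A result reported only as a limit would be no surprise. For compound 3 the estimated value is 32000 nM, with an expected range from 12000 nM to 40000 nM.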

Compound 3, half-maximal inhibitory concentration: > 40000 nM
Compound 3: no number, only a limit; the forecaster's own chance of this, stated with the estimate: 45%; at least 1.2-fold (0.09 log units) between middle value and limit.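

In this assay, hydrogen in place of chloro on an aromatic carbon gives a number no lower from compound 2 to compound 3 (the limit leaves the size open), so losing the chlorine brings no readable gain at this position, and the 4-chlorophenyl group remains the only aryl group shown here that yields an actual number. Compound 3 gives > 40000 nM, which is a limit of the assay. The step between the two compounds that carry limits, compound 1 and compound 3, cannot be read, and the set as a whole sits at the edge of what the assay can report: the limit of > 40000 nM in this assay, at which 2 of the 3 values shown sit.

The compounds shown leave open how far compound 1 and compound 3 lie beyond that limit, and so whether chloro matters at all at this position or merely places compound 2 just inside the readable range. They also leave open whether another group on this aromatic carbon, such as fluoro, methyl, an amine or a carboxylic acid, would bring a clearly lower number on the shared core.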